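From chloro to methoxy at the assay limit

The source may report more compounds than this note shows. Statements on the series, on what has been measured and on what is new or still open speak of the compounds shown alone.

In an ADME assay on BHK-21 cells (Mesocricetus auratus) for cytotoxicity, read by MTT assay (a lower number here means that less compound is tolerated, a higher number that more compound is tolerated), compound 3 (`CC(=O)c1ccc2c(c1)nc(-c1ccc(Cl)cc1)n2C1CCCCC1`) gives > 100000 nM as a limit of the assay, not a number. Compound 1 (`CC(=O)c1ccc2[nH]c(-c3ccc(Cl)cc3)nc2c1`) gives > 100000 nM as a limit too. Compound 2 (`COc1ccc(-c2nc3cc(/C(C)=N/O)ccc3[nH]2)c(OC)c1OC`) gives > 100000 nM as a limit as well. The whole picture so far is the limit of > 100000 nM in this assay, at which 3 of the 3 values shown sit, and nothing finer. Compound 4 (`COc1ccc(-c2nc3cc(C(C)=O)ccc3n2C2CCCCC2)cc1`) differs from compound 3 in one place (methoxy in place of chloro on an aromatic carbon) with methoxy in place of chloro on an aromatic carbon. Among the measured compounds shown here, the only measured step (a step that the two limits leave unreadable from compound 1 to compound 3) is a different change with no readable size, so no step beyond the scatter is expected in this assay here. The expected step (a number no higher from compound 3 to compound 4 (the limit leaves the size open)) is only an estimate. For compound 4 the estimated value is 100000 nM with a range from 50000 nM to 200000 nM and the assay may well report only a limit.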

Compound 4, half-maximal cytotoxic concentration: > 100000 nM
Compound 4 was reported as a limit (the forecaster's own chance of this, stated with the estimate: 85%); the middle value lies on the limit itself.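

Compound 3 and compound 4 are both reported only as limits, not numbers, so no size can be read for methoxy in place of chloro: the limit of > 100000 nM in this assay, at which 4 of the 4 values shown sit.

In this assay, the concentration at which any of these compounds harms the cells remains open.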